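Two limits and an unmeasured diethoxy side chain

A few compounds are considered here, and "the series" means these few. Any claim that something is new, unique, unknown or untested is made for them only; others in the source may bear on it.

Compound 1 `CC(C)=CCC[C@H](C)c1ccc(C)c2c1OCN(CCCCCO)C2`: > 20000 nM
Compound 2 `CC(C)=CCC[C@H](C)c1ccc(C)c2c1OCN(CCCCC(=O)O)C2`: > 20000 nM

In an ADME assay on MDA-MB-231 cells (Homo sapiens) for inhibition, read by MTT assay, with a stated time of 24 h (a lower number here means a stronger inhibitor, a higher number a weaker inhibitor), compound 2 gives > 20000 nM, which is a limit of the assay and not a number. Compound 1 gives > 20000 nM, which is also a limit. Together they make up the whole picture so far: the limit of > 20000 nM in this assay, at which 2 of the 2 values shown sit.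

Compound 3 `CCOC(CCN1COc2c([C@@H](C)CCC=C(C)C)ccc(C)c2C1)OCC` has not yet been measured. The change from compound 2 is diethoxymethyl in place of 2-carboxyethyl on a saturated chain carbon, two bonds along the chain from an amine nitrogen in a ring. In words, this places diethoxymethyl in place of 2-carboxyethyl on a saturated chain carbon, two bonds along the chain from an amine nitrogen in a ring.

Among the measured compounds shown here, only one measured step bears on this change, and it also alters the end of the chain: a step that the two limits leave unreadable from compound 1 to compound 2. Its size cannot be read, so it offers no measured shift to carry over. No step beyond the scatter is expected, in either direction, since compound 2 sits at the limit > 20000 nM. The estimated step is a step that the limit leaves unreadable from compound 2 to compound 3. Another limit reading is the likeliest outcome. For compound 3 the expected value is 25000 nM, with an estimated range of 10000 nM to 60000 nM.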

Compound 3, half-maximal inhibitory concentration: > 20000 nM
Compound 3 ended at the assay's limit (the forecaster's own chance of this, stated with the estimate: 75%); the middle value lies beyond the limit too.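

In this assay compound 3 gives > 20000 nM, which is a limit of the assay and not a number. Among the compounds shown here, no step among compound 1, compound 2 and compound 3 can therefore be read. The compounds shown leave open how these three compare with one another, and whether any side chain on the shared core would give a measurable value.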